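Pyrimidine in Place of a Dihalophenyl on the Amide Nitrogen

A few compounds are considered here, and "the series" means these few. Any claim that something is new, unique, unknown or untested is made for them only; others in the source may bear on it.

Compound 1 `CO[C@@H]1CC=C2NN(c3cc(Cl)cc(Cl)c3)C(=O)C[C@]2(C)O1`: in a functional assay on DU-145 cells (Homo sapiens) for inhibition, read by sulforhodamine B assay, with a stated time of 48 h (on this read-out higher numbers stand for weaker inhibition and lower numbers for stronger inhibition), compound 1 gives 21300 nM.
Compound 2 `CO[C@@H]1CC=C2NN(c3cc(F)cc(Cl)c3)C(=O)C[C@]2(c2ccccc2)O1`: in this assay compound 2 gives 16100 nM.
Compound 3 `COc1cc(OC)cc(N2NC3=CC[C@@H](OC)O[C@@]3(c3ccncc3)CC2=O)c1`: in this assay compound 3 gives 5900 nM.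

Among these three numbers compound 2 holds the second highest. Its nearest neighbour is compound 1, whose value lies within the usual scatter of compound 2, so no order between the two can be claimed. Compound 3 lies lowest, and its gap to compound 2 is beyond the scatter, so compound 3 shows the stronger inhibition of that pair. Compound 4 `CO[C@@H]1CC=C2NN(c3cncnc3)C(=O)C[C@]2(c2ccccc2)O1` is built from compound 2 by one change: pyrimidin-5-yl in place of 3-chloro-5-fluorophenyl on an amide-type nitrogen in a ring. Among the compounds with values here, no measured pair shows this kind of exchange, so there is no directly comparable step to lean on. The expectation is a step in this assay of no more than the usual scatter, with a slight lean towards weaker inhibition. Compound 4 is therefore expected to give about 20000 nM, with a range from 7000 nM to 60000 nM. This estimate corresponds to an expected step of a 1.2-fold higher number from compound 2 to compound 4 (0.09 log units; within the scatter).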

Compound 4, half-maximal inhibitory concentration: 7330 nM
The estimate for compound 4 lay 2.7-fold (0.44 log units) above the measured number; the range from low to high includes it.
By their numbers in this assay, from the lowest: compounds 3 and 4 (each within the scatter of the next); then compounds 2 and 1 (each within the scatter of the next).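

In this assay the step of a 2.2-fold lower number from compound 2 to compound 4 (0.34 log units; beyond the scatter) is modest but beyond the usual scatter, so on this amide-type nitrogen in a ring, pyrimidin-5-yl can take the place of 3-chloro-5-fluorophenyl with a gain in inhibition. The change removes both halogens and brings in a ring with 2 hetero atoms and 2 hydrogen-bond acceptors, so neither chlorine nor fluorine is required at this position for inhibition at this level. Nothing available explains why the number falls.

The compounds shown do not separate the loss of the two halogens from the arrival of the two ring nitrogens; a plain phenyl or a pyridin-3-yl group on the same nitrogen would do that. On these data alone, it also remains open how an amine on the pyrimidine ring would change the number.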